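Methyl to Tert-Butyl on the Aryl Ring

A few compounds are considered here, and "the series" means these few. Any claim that something is new, unique, unknown or untested is made for them only; others in the source may bear on it.

Of the compounds shown here, three have been measured in a functional assay on MDA-MB-231 cells (Homo sapiens) for inhibition; on this read-out higher numbers stand for weaker inhibition and lower numbers for stronger inhibition. Compound 1 `O=C1C=CC(OCC(F)(F)F)N1c1cc(Cl)cc(Cl)c1` gives 2430 nM and compound 3 `O=C1C=CC(OC(C(F)(F)F)C(F)(F)F)N1c1ccc(Cl)cc1` gives 2410 nM; compound 2 `Cc1ccc(N2C(=O)C=CC2OCC(F)(F)F)cc1` gives 15800 nM, the highest of the three numbers, beyond the scatter from each of the other two. Compound 4 `CC(C)(C)c1ccc(N2C(=O)C=CC2OCC(F)(F)F)cc1` differs from compound 2 in one place: tert-butyl in place of methyl on an aromatic carbon. Within the data shown here, no step between measured compounds isolates this change, so the expectation rests on compound 2 alone and on the spread of the other two. The step from compound 2 to compound 4 in this assay is expected to be a 3.2-fold lower number from compound 2 to compound 4 (0.50 log units; beyond the scatter), a moderate move toward stronger inhibition. Compound 4 is therefore estimated at 5000 nM in this assay, within a range of 1500 nM to 20000 nM.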

Compound 4, half-maximal inhibitory concentration: 1860 nM
Beside the measured number, compound 4's estimate is 2.7-fold (0.43 log units) above it; low and high end bracket the measured number.
By their numbers in this assay, from the lowest: compounds 4, 3 and 1 (each within the scatter of the next); then compound 2.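

In this assay, among these compounds, the change from methyl to tert-butyl on this aromatic carbon, para to a large group, gives an 8.5-fold lower number from compound 2 to compound 4 (0.93 log units; beyond the scatter) and is the first step to isolate a single change. It shows that this position tolerates the larger group and that inhibition is stronger with it. No measurement at hand explains this gain. On these data alone, whether an amine, a methoxy group or a trifluoromethyl group at the same position would match tert-butyl stays open. So does whether the gain holds with the side chain of compound 3.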